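A Nitro-Bearing Aryl Group Joins a Shared Core

The source may hold more compounds than are shown below. What is called first, only, known or untested is meant among the compounds shown, and "the series" means these compounds.

Three compounds share one core and differ only in the aryl group on a carbon with a double bond to nitrogen. Compound 1 `C[C@H]1CC[C@@H]2[C@@H](OC(=O)[C@]23CC(c2c(Cl)cccc2Cl)=NO3)[C@]2(C)C(=O)C=C[C@@]12O` gives 43000 nM in a functional assay on SW-620 cells (Homo sapiens) for cytotoxicity, read by sulforhodamine B assay, with a stated time of 48 h; on this read-out lower numbers stand for stronger inhibition and higher numbers for weaker inhibition. Compound 2 `COc1ccc(C2=NO[C@]3(C2)C(=O)O[C@@H]2[C@H]3CC[C@H](C)[C@]3(O)C=CC(=O)[C@@]23C)cc1` gives 41000 nM, the lowest of the three numbers, though a 1.0-fold lower number from compound 1 to compound 2 (0.02 log units; within the scatter) lies within the scatter, so compounds 1 and 2 cannot be told apart. Compound 3 `C[C@H]1CC[C@@H]2[C@@H](OC(=O)[C@]23CC(c2ccc(O)cc2)=NO3)[C@]2(C)C(=O)C=C[C@@]12O` gives 89000 nM; both a 2.2-fold higher number from compound 2 to compound 3 (0.34 log units; beyond the scatter) and a 2.1-fold higher number from compound 1 to compound 3 (0.32 log units; beyond the scatter) are modest. Compound 4 `C[C@H]1CC[C@@H]2[C@@H](OC(=O)[C@]23CC(c2cccc([N+](=O)[O-])c2)=NO3)[C@]2(C)C(=O)C=C[C@@]12O` carries 3-nitrophenyl in place of 4-methoxyphenyl on a carbon with a double bond to nitrogen. For the measured compounds named here, no measured step involves a 3-nitrophenyl; the closest comparison is the aryl swap a 1.0-fold lower number from compound 1 to compound 2 (0.02 log units; within the scatter), which stayed within the scatter. A step no larger than the scatter is therefore expected, a 1.0-fold higher number from compound 2 to compound 4 (0.01 log units; within the scatter). Compound 4 is estimated at 42000 nM, with a range from 20000 nM to 90000 nM.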

Compound 4, half-maximal inhibitory concentration: 49000 nM
Compound 4: middle estimate off by 1.2-fold (0.07 log units), on the low side; measured number inside the range.
By their numbers in this assay, from the lowest: compounds 2, 1, 4 and 3 (each within the scatter of the next, the first and the last beyond it).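

Putting 3-nitrophenyl on this carbon brings no step beyond the scatter in this assay from any earlier aryl group: a 1.2-fold higher number from compound 2 to compound 4 (0.08 log units; within the scatter), a 1.1-fold higher number from compound 1 to compound 4 (0.06 log units; within the scatter) and a 1.8-fold lower number from compound 3 to compound 4 (0.26 log units; within the scatter). The earlier compounds shown here showed only the 4-hydroxyphenyl of compound 3 set apart from the other two, whereas compound 4 lies within the scatter of all three. A nitro-bearing ring therefore opens no clear gap here.

Nothing available explains why these aryl groups read so alike. Going by these compounds, whether a ring carrying an amine or a carboxylic acid, or a pyridine in place of the phenyl, would shift the number remains open.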